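The source may hold more compounds than are shown below. What is called first, only, known or untested is meant among the compounds shown, and "the series" means these compounds.

Of the compounds shown here, three have so far been tested in an ADME assay on THP-1 cells (Homo sapiens) for cytotoxicity, read by trypan blue exclusion, with a stated time of 48 h; on this read-out higher numbers stand for weaker inhibition of growth and lower numbers for stronger inhibition of growth. Compound 1 `Cc1cc(CNCc2ccc(Cl)cc2)c(C)n1-c1ccc(Cl)cc1` gives 18 ug/mL. Compound 2 `Cc1cc(CN2CCN(C3C[C@@H]4CC[C@H]3C4)CC2)c(C)n1-c1ccc(Cl)cc1` gives 16 ug/mL, a number that lies within the usual scatter of that of compound 1, so the two cannot be told apart. Compound 3 `Cc1c(CN2CCN(c3ccccc3)CC2)c(CN2CCN(c3ccccc3)CC2)c(C)n1-c1ccc(Cl)cc1` gives 113 ug/mL, the highest number of the three and clearly beyond the scatter from compound 1. Compound 1 thus holds the second-highest number of the three, with compound 2 indistinguishable from it and compound 3 well above it.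

Compound 4 `Cc1cc(CNCc2ccc(F)cc2)c(C)n1-c1ccc(Cl)cc1` has not yet been measured in this assay. It differs from compound 1 in one place: fluoro in place of chloro on an aromatic carbon. For the measured compounds named here, no pair of measured compounds shows the effect of this change, so there is no direct guide in these data. The change swaps one heavy atom for one heavy atom, with no ring, no hydrogen-bond donor or acceptor and no charge gained or lost, so the expected step is a 1.2-fold higher number from compound 1 to compound 4 (0.09 log units; within the scatter), at most around the edge of the scatter. Compound 4 is therefore expected to give 22 ug/mL, within a range from 10 ug/mL to 50 ug/mL.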

Compound 4, concentration for 50% growth inhibition: 8.4 ug/mL
The estimate for compound 4 lay 2.6-fold (0.42 log units) above the measured number, outside the stated range (below it).
By their numbers in this assay, from the lowest: compounds 4, 2 and 1 (each within the scatter of the next, the first and the last beyond it); then compound 3.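

In this assay, fluoro in place of chloro on the 4-chlorobenzyl group gives a 2.1-fold lower number from compound 1 to compound 4 (0.33 log units; beyond the scatter) and so moves the read-out modestly towards stronger inhibition of growth. For the compounds shown here, this is the first pair of compounds here that differ in one place, and it shows that exchanging one halogen atom for another at this position, with no change in the counts of rings, hydrogen-bond donors or acceptors, can take the number just beyond the usual scatter. No measurement available here accounts for this step.

On these data alone, whether other groups at this place, such as bromo, methyl, methoxy or plain hydrogen, would lower the number further or raise it again remains open. Also open, as far as these compounds go, is whether the 4-chlorophenyl group, which all four compounds carry, would respond in the same way to the same exchange.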